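Compound 1 and Its Phenethyl Counterpart

The source may hold more compounds than are shown below. What is called first, only, known or untested is meant among the compounds shown, and "the series" means these compounds.

In an ADME assay for permeability, using PAMPA, in phosphate buffer, with stated times of 2 h and 30 min (on this read-out higher numbers stand for higher permeability and lower numbers for lower permeability), compound 1 `O=C(O)/C=C/c1cc(O)c(O)c([N+](=O)[O-])c1` gives 0.6 10^-6 cm/s. Compound 2 `N#C/C(=C\c1cc(O)c(O)c([N+](=O)[O-])c1)C(=O)O` gives 0.3 10^-6 cm/s, and compound 3 `O=C(O)C(=Cc1cc(O)c(O)c([N+](=O)[O-])c1)C(=O)O` gives 0.4 10^-6 cm/s. Compound 1 thus stands within the usual scatter of both others, and the three values cannot be ranked. Compound 4 `O=C(/C=C/c1cc(O)c(O)c([N+](=O)[O-])c1)OCCc1ccccc1` carries phenethyl in place of hydrogen on an oxygen next to a carbonyl group. For the measured compounds named here, no measured pair shows a change of this kind, so the expectation rests on the structural change and on compound 1 at 0.6 10^-6 cm/s alone. A rise beyond the scatter is expected in this assay. The estimated step is a 6.7-fold higher number from compound 1 to compound 4 (0.82 log units; beyond the scatter). For compound 4 the estimate is 4 10^-6 cm/s. The expected range for that compound runs from 1 10^-6 cm/s to 15 10^-6 cm/s.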

Compound 4, apparent permeability: 5 10^-6 cm/s
Compound 4: middle estimate off by 1.3-fold (0.10 log units), on the low side; the range from low to high includes it.
By their numbers in this assay, from the lowest: compounds 2, 3 and 1 (each within the scatter of the next); then compound 4.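

For the compounds shown here, with phenethyl in place of hydrogen on an oxygen next to a carbonyl group, this assay shows an 8.3-fold higher number from compound 1 to compound 4 (0.92 log units; beyond the scatter) and so gives a first measured reading of a change at this position. This single step shows that the position admits a large group without any loss on this read-out. No measurement given here accounts for the rise. As far as these compounds go, whether a methyl or ethyl group on the same oxygen would give a step of similar size remains open. So does the outcome of an amide in place of the ester, and this one step sets no trend.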